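The source may hold more compounds than are shown below. What is called first, only, known or untested is meant among the compounds shown, and "the series" means these compounds.

Of the compounds shown here, three built on one shared core have been tested so far. Compound 1 `Cc1c(C(=O)Nc2c(F)cc(-c3cccc(F)c3)cc2F)nc2ccc(F)cc2c1O` carries a fluoro group on the carbon-only ring of the fused system, and in a functional assay on Hep 3B2 cells (Homo sapiens) for antiproliferative activity, read by MTT assay, with a stated time of 24 h, tested at 0.02 ug/mL (a higher number here means a stronger effect of the compound at the concentration tested, a lower number a weaker effect), compound 1 gives 0.35%. Compound 2 `CCOc1ccc2nc(C(=O)Nc3c(F)cc(-c4cccc(F)c4)cc3F)c(C)c(O)c2c1` differs from compound 1 by ethoxy in place of fluoro on an aromatic carbon. In this assay compound 2 gives -0.32%, and the step is a number 0.7 percentage points lower from compound 1 to compound 2 (within the scatter). Compound 3 `Cc1c(C(=O)Nc2c(F)cc(-c3cccc(F)c3)cc2F)nc2ccc(F)cc2c1C(=O)O` differs from compound 1 by carboxy in place of hydroxy on an aromatic carbon, and this is also the full account of how the core of compound 3 differs from the core of compound 1. In this assay compound 3 gives -0.13%, with the step of a number 0.5 percentage points lower from compound 1 to compound 3 (within the scatter). Going by the values given here, all three values sit within the usual scatter of one another, so no compound can be called stronger or weaker than another.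

Compound 4 `CCOc1ccc2nc(C(=O)Nc3c(F)cc(-c4cccc(F)c4)cc3F)c(C)c(C(=O)O)c2c1` has not yet been measured. It differs from compound 3 by ethoxy in place of fluoro on an aromatic carbon. This is the same change as that from compound 1 to compound 2, and the two places read word for word the same. Its earlier occurrence changed little, because a number 0.7 percentage points lower from compound 1 to compound 2 (within the scatter) stayed within the scatter. On that basis the step expected here is a number 0.4 percentage points lower from compound 3 to compound 4 (within the scatter). Compound 4 is therefore expected to give about -0.5% in this assay, with a likely range from -8% to 7%.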

Compound 4, a percentage reported as inhibition, at one concentration (the size of the read-out at that concentration, not a potency): 0.05%
Compound 4: the middle estimate sits 0.6 percentage points below what was measured; measured number inside the range.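

On the core of compound 3, ethoxy in place of fluoro on an aromatic carbon gives a number 0.2 percentage points higher from compound 3 to compound 4 (within the scatter) in this assay, and this agrees with the earlier occurrence of the same change: the same change on two cores in this assay, a number 0.7 percentage points lower (within the scatter) from compound 1 to compound 2 and a number 0.2 percentage points higher (within the scatter) from compound 3 to compound 4, 0.9 percentage points apart, within the scatter of two such steps. Carboxy in place of hydroxy on an aromatic carbon, now on an ethoxy-bearing core, gives a number 0.4 percentage points higher from compound 2 to compound 4 (within the scatter), and it too agrees with its earlier occurrence: the same change on two cores in this assay, a number 0.5 percentage points lower (within the scatter) from compound 1 to compound 3 and a number 0.4 percentage points higher (within the scatter) from compound 2 to compound 4, 0.9 percentage points apart, within the scatter of two such steps. Going by these compounds alone, this shows that neither change produced a step beyond the scatter on either core, but it does not show that an effect carries from one core to another, since no step here is large enough to be told from the scatter and the differing directions of the paired steps carry no meaning.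

The compounds shown leave open whether another group at the place of the fluoro or ethoxy, such as an amine or a longer alkoxy chain, or an ester or amide at the place of the carboxy, would give a step beyond the scatter in this assay. They also leave open how these changes would read at any other concentration, as all four compounds are compared at a single one.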